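Replacing a halogenated phenyl group with a dihydroxyphenyl group

A few compounds are considered here, and "the series" means these few. Any claim that something is new, unique, unknown or untested is made for them only; others in the source may bear on it.

In a functional assay on K562 cells (Homo sapiens) for antiproliferative activity, with a stated time of 72 h (a higher number here means a weaker inhibitor, a lower number a stronger inhibitor), three compounds sharing one core differ only in their substituted phenyl group. Compound 1 `OC[C@H]1O[C@@H](n2cnc3c(NCc4ccccc4Cl)ncnc32)[C@H](O)[C@@H]1O` gives 64000 nM, compound 2 `OC[C@H]1O[C@@H](n2cnc3c(NCc4ccc(Cl)c(Cl)c4)ncnc32)[C@H](O)[C@@H]1O` gives 10800 nM, and compound 3 `OC[C@H]1O[C@@H](n2cnc3c(NCc4ccc(F)cc4Cl)ncnc32)[C@H](O)[C@@H]1O` gives 15600 nM. Compound 3 is level with compound 2, with a 1.4-fold higher number from compound 2 to compound 3 (0.16 log units; within the scatter), and clearly better than compound 1, with a 4.1-fold lower number from compound 1 to compound 3 (0.61 log units; beyond the scatter).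

Compound 4 `OC[C@H]1O[C@@H](n2cnc3c(NCc4cc(O)cc(O)c4)ncnc32)[C@H](O)[C@@H]1O` alters that same group: 3,5-dihydroxyphenyl in place of 2-chloro-4-fluorophenyl on a saturated chain carbon bound to a nitrogen on an aromatic ring. In words, 3,5-dihydroxyphenyl stands in place of 2-chloro-4-fluorophenyl.

The closest guide is a 5.9-fold lower number from compound 1 to compound 2 (0.77 log units; beyond the scatter), which shows that changing this group can produce a modest step. Among the measured compounds shown here, that step and the one from compound 1 to compound 3 only rearrange halogens, and no measured compound carries a hydroxy group, so the direction is a cautious judgement. A modest move toward a higher number is expected. The estimated change is a 2.6-fold higher number from compound 3 to compound 4 (0.41 log units; beyond the scatter). For compound 4 the estimated value is 40000 nM, with an expected range of 12000 nM to 130000 nM.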

Compound 4, half-maximal inhibitory concentration: > 166000 nM
Compound 4: only a limit was reported; the forecaster's own chance of this, stated with the estimate: 25%; middle value at least 4.1-fold (0.61 log units) away from the limit.
By their numbers in this assay, from the lowest: compounds 2 and 3 (each within the scatter of the next); then compound 1. At a limit, above all of these: compound 4.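

In this assay, among the compounds shown here, the earlier compounds carried only halogens on this phenyl group, and changing those halogens gave modest steps at most, whereas the 3,5-dihydroxyphenyl group gives large ones: an at least 10-fold higher number from compound 3 to compound 4 (1.02 log units; beyond the scatter) and an at least 15-fold higher number from compound 2 to compound 4 (1.18 log units; beyond the scatter). Even compound 1, which has the highest number of the three halogenated compounds, stands clearly apart, with an at least 2.5-fold higher number from compound 1 to compound 4 (0.41 log units; beyond the scatter). The value of compound 4 is a limit, not a number: the limit of > 166000 nM in this assay, at which 1 of the 4 values shown sits.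

The compounds shown leave open how far compound 4 truly lies from the others, and whether the loss comes from gaining the hydroxy groups or from losing the halogens. An unsubstituted phenyl group, or a phenyl group carrying a methoxy group or an amine, could help separate those two changes.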